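Swapping the Ring on the Amide Nitrogen: Cytotoxicity Outlook

The compounds below may be only part of what the source reports. "The series", "measured", "known", "first", "only" and "open" are said of these compounds alone.

Of the compounds shown here, three built on one shared core have been tested in a functional assay on HEK293 cells (Homo sapiens) for cytotoxicity; a lower number here means that less compound is tolerated, a higher number that more compound is tolerated. Compound 1 `COc1ccc([C@H]2CC(=O)N(Cc3cccc([N+](=O)[O-])c3)C2)cc1OC1CCCC1` carries a 3-nitrobenzyl group on an amide-type nitrogen in a ring; in this assay compound 1 gives > 10000 nM, which is a limit of the assay rather than a number. Compound 2 `COc1ccc([C@H]2CC(=O)N(c3ccccc3)C2)cc1OC1CCCC1` carries a phenyl at that position, and in this assay compound 2 gives > 10000 nM, again a limit. Compound 3 `COc1ccc([C@H]2CC(=O)N(c3cccc(N)c3C)C2)cc1OC1CCCC1` carries a 3-amino-2-methylphenyl there, and in this assay compound 3 gives > 10000 nM, also a limit. Compound 3 thus stands exactly where the other two stand, at the limit of > 10000 nM in this assay, at which 3 of the 3 values shown sit.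

The steps between these compounds, a step that the two limits leave unreadable from compound 1 to compound 2, a step that the two limits leave unreadable from compound 1 to compound 3 and a step that the two limits leave unreadable from compound 2 to compound 3, cannot be sized because every compound sits at the limit of > 10000 nM in this assay, at which 3 of the 3 values shown sit.

Compound 4 `COc1ccc([C@H]2CC(=O)N(c3ccc(C#N)cc3)C2)cc1OC1CCCC1` differs from compound 3 by 4-cyanophenyl in place of 3-amino-2-methylphenyl on an amide-type nitrogen in a ring. All three measured steps change the same position and none is readable, so no size can be carried over. The expectation is that compound 4 stays at the limit as well, with the step that the limit leaves unreadable from compound 3 to compound 4 expected to be too small to see. Compound 4 is estimated at 20000 nM, within 10000 nM to 60000 nM, and will most likely be reported again only as a limit.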

Compound 4, half-maximal cytotoxic concentration: > 10000 nM
Compound 4: no number, only a limit (the forecaster's own chance of this, stated with the estimate: 85%); the middle value lies beyond the limit too.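

In this assay compound 4 gives > 10000 nM as a limit of the assay and not a number. For the compounds shown here, no step from compound 4 to compound 1, compound 2 or compound 3 can be read, because all four compounds share this one limit: (the limit of > 10000 nM in this assay, at which 4 of the 4 values shown sit). Still open, going by these compounds, is whether any group on the amide-type nitrogen would give a measurable value, and how far such values would differ.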